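Swapping a Pyrimidine for an Isoxazole on a Weak Inhibitor

A few compounds are considered here, and "the series" means these few. Any claim that something is new, unique, unknown or untested is made for them only; others in the source may bear on it.

Of the compounds shown here, two have been measured, and both sit at the edge of what the test can report. Compound 1 `Cn1c(-c2ccc(-c3cncnc3)cc2)nnc1C1(c2ccc(Cl)cc2)CCC1` carries a pyrimidin-5-yl group on the outer aromatic ring of its core. In an assay on isolated protein for inhibition of 11-beta-hydroxysteroid dehydrogenase type 2 (Homo sapiens) (a higher number here means a weaker inhibitor, a lower number a stronger inhibitor), compound 1 gives only a limit of the measurement, > 4000 nM. Compound 2 `Cn1c(-c2ccc(C(=O)O)cc2Cl)nnc1C1(c2ccc(Cl)cc2)CCC1` replaces that group with a carboxylic acid and adds a chlorine on the same ring. In this assay compound 2 likewise gives only a limit, > 4000 nM. Both values therefore say the same thing: neither compound inhibits strongly enough to yield a number, a point summed up by the limit of > 4000 nM in this assay, at which 2 of the 2 values shown sit.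

Compound 3 `Cc1noc(C)c1-c1ccc(-c2nnc(C3(c4ccc(Cl)cc4)CCC3)n2C)cc1` is not yet measured. It differs from compound 1 in one place, (3,5-dimethyl-1,2-oxazol-4-yl in place of pyrimidin-5-yl on an aromatic carbon), in words a 3,5-dimethyl-1,2-oxazol-4-yl in place of pyrimidin-5-yl on an aromatic carbon. Among the measured compounds shown here, with no measured step available, no direction can be read from the data, and the expected step from compound 1 to compound 3 is a step that the limit leaves unreadable from compound 1 to compound 3, within the scatter. Compound 3 is expected to give about 6000 nM in this assay, between 1500 nM and 25000 nM, most likely again only a limit.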

Compound 3, half-maximal inhibitory concentration: > 4000 nM
Compound 3 was reported as a limit (the forecaster's own chance of this, stated with the estimate: 70%); the middle value lies beyond the limit too.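

No step can be read between compound 1 and compound 3, because both results are only limits rather than numbers: the limit of > 4000 nM in this assay, at which 3 of the 3 values shown sit.

The compounds shown leave open what number any of them would give in this assay, and so whether 3,5-dimethyl-1,2-oxazol-4-yl in place of pyrimidin-5-yl changes the inhibition at all.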